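The compounds below may be only part of what the source reports. "The series", "measured", "known", "first", "only" and "open" are said of these compounds alone.

In a functional assay on CCRF-CEM cells (Homo sapiens) for cytotoxicity, read by cell counting, with a stated time of 3 days (a higher number here means a weaker inhibitor, a lower number a stronger inhibitor), compound 1 `Nc1ccc(/C=C2\SC(=O)N(Cc3ccc(Cl)cc3)C2=O)cc1` gives 87000 nM, the second highest of the three numbers recorded so far. Compound 2 `CC(C)(C)c1ccc(CN2C(=O)S/C(=C\c3cccc(N)c3)C2=O)cc1` gives 165000 nM, the nearest to compound 1, and the two values fall within the scatter of each other. Compound 3 `C=C(Br)C(=O)Nc1ccc(/C=C2\SC(=O)N(Cc3ccccc3)C2=O)cc1` gives 2300 nM, a number far lower than that of compound 1 and well beyond the scatter. Compound 4 `Nc1ccc(/C=C2\SC(=O)N(Cc3ccc(F)cc3)C2=O)cc1` differs from compound 1 in one place: fluoro in place of chloro on an aromatic carbon. Within the data shown here, no measured pair in this set shows that exchange, so there is no step to lean on. A small step is expected, a 1.1-fold higher number from compound 1 to compound 4 (0.06 log units; within the scatter), in no direction beyond the scatter. Compound 4 is therefore estimated at 100000 nM, within a range from 40000 nM to 250000 nM.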

Compound 4, half-maximal inhibitory concentration: 111000 nM
For compound 4 the middle estimate is 1.1-fold (0.05 log units) below the measured one; low and high end bracket the measured number.
By their numbers in this assay, from the lowest: compound 3; then compounds 1, 4 and 2 (each within the scatter of the next).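

In this assay, putting fluoro in place of chloro gives a 1.3-fold higher number from compound 1 to compound 4 (0.11 log units; within the scatter), so the two groups cannot be told apart at this place on the aromatic ring. This is the only single-place comparison among the compounds shown, and it covers this one exchange alone. Nothing at hand bears on the reason for this result.

As far as these compounds go, whether a methoxy, a trifluoromethyl or an amine at this place would give a number beyond the scatter stays open. Also open, from the compounds shown here alone, is whether fluoro and chloro would match in a compound carrying the bromo-substituted acrylamide of compound 3.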